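The compounds below may be only part of what the source reports. "The series", "measured", "known", "first", "only" and "open" are said of these compounds alone.

Compound 3 `Cn1ccc2cc(-c3ccc4oc(Nc5cccnc5)nc4c3)ccc21` gives 226 nM in an assay on HEK293 cells for inhibition of Fatty-acid amide hydrolase 1 (Homo sapiens), read by fluorescence (a higher number here means a weaker inhibitor, a lower number a stronger inhibitor), the lowest of the three numbers measured. Compound 2 `COc1ccc(Nc2nc3cc(-c4ccc5c(ccn5C)c4)ccc3o2)cc1` gives 280 nM, and the two lie within the scatter of each other, the step being a 1.2-fold lower number from compound 2 to compound 3 (0.09 log units; within the scatter). Compound 1 `Cn1ccc2cc(-c3ccc4oc(NC5CCCCC5)nc4c3)ccc21` gives 911 nM; the step of a 4.0-fold lower number from compound 1 to compound 3 (0.61 log units; beyond the scatter) lies beyond the scatter, as does a 3.3-fold lower number from compound 1 to compound 2 (0.51 log units; beyond the scatter). Compound 4 `Cn1ccc2cc(-c3ccc4oc(N5CCCC5)nc4c3)ccc21` carries pyrrolidin-1-yl in place of (pyridin-3-yl)amino on an aromatic carbon. Within the data shown here, no measured step removes the hydrogen-bond donor of the (pyridin-3-yl)amino group; the nearest guide is compound 1, whose cyclohexyl partner gave the highest number, and its step of a 4.0-fold lower number from compound 1 to compound 3 (0.61 log units; beyond the scatter). Compound 4 is therefore expected to show a step of a 6.6-fold higher number from compound 3 to compound 4 (0.82 log units; beyond the scatter), its number rising toward the region of compound 1. Compound 4 is estimated at 1500 nM, with a range of 400 nM to 6000 nM.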

Compound 4, half-maximal inhibitory concentration: 674 nM
Estimate against measurement, compound 4: 2.2-fold (0.35 log units) above; the range from low to high includes it.
By their numbers in this assay, from the lowest: compounds 3 and 2 (each within the scatter of the next); then compounds 4 and 1 (each within the scatter of the next).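

In this assay, pyrrolidin-1-yl, which carries no hydrogen-bond donor, gives a 3.0-fold higher number from compound 3 to compound 4 (0.47 log units; beyond the scatter) and a 2.4-fold higher number from compound 2 to compound 4 (0.38 log units; beyond the scatter) against the two aromatic amino groups. Against cyclohexylamino it gives a 1.4-fold lower number from compound 1 to compound 4 (0.13 log units; within the scatter), so compound 4 without the donor cannot be told apart from compound 1 with it, and the donor alone does not separate the numbers at this position. No measurement here gives a cause for these steps. Open, as far as these compounds go, is whether a morpholine ring or a dimethylamino group on this aromatic carbon would match compound 4, and whether a benzylamino group would match compound 3.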